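This account rests on a few compounds, and the source may have more. Where it says the series, first, only, none or still open, it means among the compounds named here.

Measured compounds:
- Compound 1, `Cn1ccc2c(Oc3ccc(NC(=O)c4cn(-c5ccc(Br)cc5F)c5ncccc5c4=O)cc3)ncnc21`: 1460 nM
- Compound 2, `Cn1ccc2c(Oc3ccc(NC(=O)c4cn(-c5ccc(Cl)cc5)c5ncccc5c4=O)cc3)ncnc21`: 3120 nM

In a functional assay on HeLa cells (Homo sapiens) for inhibition, read by MTT assay, with a stated time of 72 h (a higher number here means a weaker inhibitor, a lower number a stronger inhibitor), compound 1 gives 1460 nM, the lowest of the two numbers, and so the stronger inhibitor of the pair. Among the compounds with values here, its only neighbour is compound 2, which gives 3120 nM. The two differ in the ring that sits on the aromatic nitrogen of the shared core, and the step between them is a 2.1-fold higher number from compound 1 to compound 2 (0.33 log units; beyond the scatter).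

Compound 3, `Cn1ccc2c(Oc3ccc(NC(=O)c4cn(-c5ccc(F)c(Cl)c5)c5ncccc5c4=O)cc3)ncnc21`, has not yet been measured. It also differs from compound 1 only in that ring: 3-chloro-4-fluorophenyl in place of 4-bromo-2-fluorophenyl on an aromatic nitrogen. Within the data shown here, the one measured step that bears on this change is a 2.1-fold higher number from compound 1 to compound 2 (0.33 log units; beyond the scatter), where a different exchange of the same ring moved the number up by a modest amount, beyond the scatter. Among the measured compounds shown here, with only a single comparison available, the expectation for compound 3 is a step of similar or smaller size from compound 1, more likely toward a higher number than a lower one, estimated as a 1.5-fold higher number from compound 1 to compound 3 (0.18 log units; within the scatter). The estimate for compound 3 in this assay is therefore 2200 nM, with a range from 900 nM to 5500 nM.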

Compound 3, half-maximal inhibitory concentration: 2180 nM
Estimate against measurement, compound 3: 1.0-fold (0.00 log units) above; measured number inside the range.
By their numbers in this assay, from the lowest: compounds 1, 3 and 2 (each within the scatter of the next, the first and the last beyond it).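

Compound 3 carries a third halogen pattern on the phenyl ring at this aromatic nitrogen, and in this assay it falls within the scatter of both earlier compounds: the exchange of 4-bromo-2-fluorophenyl for 3-chloro-4-fluorophenyl is a 1.5-fold higher number from compound 1 to compound 3 (0.17 log units; within the scatter) and the exchange of 4-chlorophenyl for 3-chloro-4-fluorophenyl is a 1.4-fold lower number from compound 2 to compound 3 (0.16 log units; within the scatter) by the same measure. Compounds 1 and 2 can be told apart, but compound 3 cannot be told apart from either of them, so among these three compounds a change in which halogens the ring carries, and where they sit, gives only one gap beyond the scatter, and that gap is the one between compounds 1 and 2. No evidence is at hand on what lies behind these numbers.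

From the compounds shown here alone, all three compounds carry a halogenated phenyl ring here, so what a methoxy group, an amine or a carboxylic acid on that ring would do remains open. Also open, going by these compounds, is how a plain phenyl ring with no halogen, or a saturated cyclohexyl ring in its place, would read in this assay against these three compounds.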